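The compounds below may be only part of what the source reports. "The series", "measured", "known", "first", "only" and "open" are said of these compounds alone.

Compound 3 `CC(C)N(C(=S)SCc1coc2ccccc2c1=O)C(C)C` carries only a hydrogen on the outer aromatic ring where compound 1 `Cc1ccc2c(=O)c(CSC(=S)N(C(C)C)C(C)C)coc2c1` carries a methyl. In a functional assay on HeLa cells (Homo sapiens) for antiproliferative activity, read by MTT assay, with a stated time of 72 h (on this read-out higher numbers stand for weaker inhibition and lower numbers for stronger inhibition), compound 1 gives 1400 nM. For compound 3 this assay reports only a limit, > 30000 nM, not a number. The step of an at least 21-fold higher number from compound 1 to compound 3 (1.33 log units; beyond the scatter) therefore shows a large loss on removing that methyl. Compound 2 `O=c1c(CSC(=S)N2CCCC2)coc2cc(Cl)ccc12`, which carries a chloro on the same ring but a pyrrolidine in place of the diisopropylamine, gives 1300 nM in this assay. Compound 4 `CC(C)N(C(=S)SCc1coc2cc(Cl)ccc2c1=O)C(C)C` differs from compound 3 by chloro in place of hydrogen on an aromatic carbon. Given an at least 21-fold higher number from compound 1 to compound 3 (1.33 log units; beyond the scatter) and the value of compound 2, a large gain is expected, so that compound 4 is estimated at 1500 nM, within 500 nM to 8000 nM, a step of an at least 20-fold lower number from compound 3 to compound 4 (1.30 log units; beyond the scatter).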

Compound 4, half-maximal inhibitory concentration: > 25000 nM
Compound 4: only a limit was reported; the forecaster's own chance of this, stated with the estimate: 15%; at least 16-fold (1.22 log units) between middle value and limit.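

Chloro in place of methyl on this aromatic carbon gives an at least 17-fold higher number from compound 1 to compound 4 (1.25 log units; beyond the scatter), so with the diisopropylamino group kept, chloro does not stand in for the methyl. With the chloro kept, diisopropylamino in place of pyrrolidin-1-yl gives an at least 19-fold higher number from compound 2 to compound 4 (1.28 log units; beyond the scatter), so the activity of compound 2 in this assay depends on the amine as well as on the ring substituent. Compound 4 and compound 3 are both reported only as limits, so the step between them cannot be read.

As far as these compounds go, it remains open whether methyl would also serve alongside pyrrolidin-1-yl, and whether an ethyl or methoxy group on this carbon would match the methyl.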